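From a limit toward a number: compound 4

The source may report more compounds than this note shows. Statements on the series, on what has been measured and on what is new or still open speak of the compounds shown alone.

In a functional assay on SGC-7901 cells (Homo sapiens) for antiproliferative activity, read by MTT assay, with a stated time of 24 h (a lower number here means a stronger inhibitor, a higher number a weaker inhibitor), compound 1 `O=C(NNc1ccc(F)cc1)c1ccccc1NS(=O)(=O)c1cnc(O)nc1O` gives > 20000 nM. That value is a limit of the assay, not a number. Compound 3 `O=C(NNC(=O)c1ccc(NS(=O)(=O)c2cnc(O)nc2O)cc1)c1ccc(F)cc1` gives > 20000 nM, which is also a limit. Compound 1 therefore stands at the limit of > 20000 nM in this assay, at which 2 of the 3 values shown sit. Only compound 2 `O=C(NNC(=O)c1cccc(Cl)c1)c1ccc(NS(=O)(=O)c2cnc(O)nc2O)cc1` returns an actual number, at 8610 nM.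

Compound 4 `O=C(NNC(=O)c1ccccc1NS(=O)(=O)c1cnc(O)nc1O)c1cccc(Cl)c1` differs from compound 1 by one structural change: (3-chlorophenyl)carbonyl in place of 4-fluorophenyl on an amine nitrogen. Put simply, (3-chlorophenyl)carbonyl replaces 4-fluorophenyl on an amine nitrogen.

Among the measured compounds shown here, one measured step bears on this change. It is an at least 2.3-fold higher number from compound 2 to compound 3 (0.36 log units; beyond the scatter), with 4-fluorophenyl in place of 3-chlorophenyl on a carbonyl carbon. Read in reverse, this single pair links the 3-chlorophenyl group to the lower number, and compound 4 carries the same (3-chlorophenyl)carbonyl group as compound 2. The guide is a loose one, since the step is modest and the change in compound 4 happens on an amine nitrogen instead. A modest move toward stronger inhibition is expected, and compound 4 could still end up at the limit. The expected size of the change is an at least 1.8-fold lower number from compound 1 to compound 4 (0.25 log units; that floor lies within the scatter). For compound 4 the estimate is 11000 nM, with an expected range from 4500 nM to 26000 nM.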

Compound 4, half-maximal inhibitory concentration: 1820 nM
Beside the measured number, compound 4's estimate is 6.0-fold (0.78 log units) above it; measured number below the stated range.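

Among the compounds shown here, exchanging 4-fluorophenyl for (3-chlorophenyl)carbonyl on this amine nitrogen gives an at least 10-fold lower number from compound 1 to compound 4 (1.04 log units; beyond the scatter) in this assay, so the group at this position can strongly change the result, whereas the only earlier step concerned a group on a carbonyl carbon. Compound 1 sits at a limit of the assay and not at a number, so this step gives only a floor for the true difference: the limit of > 20000 nM in this assay, at which 2 of the 4 values shown sit.

For the compounds shown here, compound 4 also brings a second actual number into the set, and both compounds that return a number so far, compound 2 and compound 4, carry the (3-chlorophenyl)carbonyl group.

The change from compound 1 to compound 4 alters two things at once, adding a carbonyl and replacing a fluorine-bearing ring with a chlorine-bearing one, and the compounds shown do not separate these two contributions. As far as these compounds go, a plain benzoyl group, a (4-fluorophenyl)carbonyl group or a small acetyl group on the same nitrogen would be the natural comparisons, and how any of them would read remains open.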